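Swapping a substituted benzyl ether for a small allyl group

This account rests on a few compounds, and the source may have more. Where it says the series, first, only, none or still open, it means among the compounds named here.

Compound 2 `CC(C)c1ccc(COc2ccccc2C2CC(=O)c3ccccc3O2)cc1` stands highest of the two numbers in a functional assay on RAW264.7 cells (Mus musculus) for inhibition, read by immunoassay, with a stated time of 12 h, tested at 30 uM (a higher number here means more inhibition at the concentration tested (going by the name of the read-out), a lower number less inhibition), giving 91.5%; compound 1 `O=C1CC(c2ccccc2OCc2ccc(F)cc2)Oc2ccccc21` gives 45.2%. Compound 3 `C=CCOc1ccccc1C1CC(=O)c2ccccc2O1` is not yet measured. It differs from compound 2 in this way: vinyl in place of 4-isopropylphenyl on a saturated chain carbon bound to an oxygen on an aromatic ring. Among the measured compounds shown here, the only measured step, a number 46.3 percentage points higher from compound 1 to compound 2 (beyond the scatter), changed the group on the aromatic ring that now leaves altogether, so it bears only loosely on this change. A downward step beyond the scatter is therefore expected, a number 46.5 percentage points lower from compound 2 to compound 3 (beyond the scatter), with compound 3 estimated at 45%, between 20% and 70%.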

Compound 3, a percentage reported as inhibition, at one concentration (the size of the read-out at that concentration, not a potency): 49.3%
Compound 3: middle estimate off by 4.3 percentage points, on the low side, and the stated range covers the measured number.
By their numbers in this assay, from the lowest: compounds 1 and 3 (each within the scatter of the next); then compound 2.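

Going from the 4-isopropylphenyl to the much smaller vinyl gives a number 42.2 percentage points lower from compound 2 to compound 3 (beyond the scatter) and shows that the high number at this position depends on what sits there. The same swap from the 4-fluorophenyl gives a number 4.1 percentage points higher from compound 1 to compound 3 (within the scatter) and leaves the two groups indistinguishable. An aromatic ring at this place therefore does not by itself bring the high number, as only the ring with isopropyl does so among these three compounds.

Nothing available explains why that ring stands apart. From the compounds shown here alone, whether a tert-butyl on that ring would keep the high number, or a propyl chain would read like vinyl, stays open.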